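The compounds below may be only part of what the source reports. "The series", "measured", "known", "first", "only" and "open" are said of these compounds alone.

Measured in a functional assay on HL-60 cells (Homo sapiens) for antiproliferative activity, read by MTT assay, with a stated time of 48 h; on this read-out lower numbers stand for stronger inhibition and higher numbers for weaker inhibition:
- Compound 1 `CN(C)CCn1c(N)c(-c2nc3ccccc3n2C)c2nc(C#N)c(C#N)nc21`: > 50000 nM (a limit, not a number)
- Compound 2 `CN(C)CCCn1c(N)c(-c2nc3ccccc3n2C)c2nc(C#N)c(C#N)nc21`: 2120 nM

Among the compounds with values here, compound 2 holds the only actual number in this assay. Compound 3 `CCN(CC)CCCCn1c(N)c(-c2nc3ccccc3n2C)c2nc(C#N)c(C#N)nc21` carries 4-(diethylamino)butyl in place of 3-(dimethylamino)propyl: (diethylamino)methyl in place of dimethylamino on a saturated chain carbon, three bonds along the chain from an aromatic nitrogen.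

Within the data shown here, the only measured step on this chain, an at least 23-fold lower number from compound 1 to compound 2 (1.37 log units; beyond the scatter), is large but starts from a limit, (the limit of > 50000 nM in this assay, at which 1 of the 2 values shown sits), so its true size stays open. A much smaller step towards a lower number is expected in this assay, possibly not beyond the scatter. The estimate is a 1.8-fold lower number from compound 2 to compound 3 (0.25 log units; within the scatter). For compound 3 the expected value is 1200 nM, within an estimated range of 300 nM to 6000 nM.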

Compound 3, half-maximal inhibitory concentration: 700 nM
Estimate against measurement, compound 3: 1.7-fold (0.23 log units) above; low and high end bracket the measured number.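

In this assay, within the data shown here, the change from 3-(dimethylamino)propyl to 4-(diethylamino)butyl gives a 3.0-fold lower number from compound 2 to compound 3 (0.48 log units; beyond the scatter) and so provides the first step between two actual numbers, one that is modest but beyond the scatter. The wider step of an at least 71-fold lower number from compound 1 to compound 3 (1.85 log units; beyond the scatter) is only a bound, and its true size stays open: the limit of > 50000 nM in this assay, at which 1 of the 3 values shown sits.

Chain and amine change together here, so the shares of the longer chain and of diethylamino over dimethylamino remain open. Also open, as far as these compounds go, is how a ring amine such as piperidine or morpholine, or a chain longer than butyl, would read.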